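From methyl to piperidin-1-yl on the shared core

The compounds below may be only part of what the source reports. "The series", "measured", "known", "first", "only" and "open" are said of these compounds alone.

In a functional assay on HCT-15 cells (Homo sapiens) for cytotoxicity, read by MTT assay, with a stated time of 2 days (on this read-out lower numbers stand for stronger inhibition and higher numbers for weaker inhibition), compound 1 `Cc1ccc2nc(-c3ccccc3N(C)C)[nH]c(=O)c2c1` reads > 50000 nM as a limit of the assay and not a number. Compound 2 `CN(C)c1ccc2nc(-c3cccc4ccccc34)[nH]c(=O)c2c1` gives 460 nM in this assay as a true number. Compound 3 `Cc1ccc2nc(-c3cccc4ccccc34)[nH]c(=O)c2c1` reads > 50000 nM as a limit of the assay as well. Compound 3 thus sits at the limit of > 50000 nM in this assay, at which 2 of the 3 values shown sit, and has no number of its own.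

Compound 4 `O=c1[nH]c(-c2cccc3ccccc23)nc2ccc(N3CCCCC3)cc12` has not yet been measured. It carries piperidin-1-yl in place of methyl on an aromatic carbon of compound 3, and the change counts as piperidin-1-yl in place of methyl on an aromatic carbon in all.

Going by the values given here, one measured step bears on this change. It is an at least 100-fold higher number from compound 2 to compound 3 (2.03 log units; beyond the scatter) and it comes with methyl in place of dimethylamino on an aromatic carbon. Compound 4 loses that methyl too, but piperidin-1-yl is not dimethylamino, so this large step serves as a guide and not as a measure.

A large move towards lower numbers is therefore expected, though it can only be counted from a limit. The expected size is an at least 33-fold lower number from compound 3 to compound 4 (1.52 log units; beyond the scatter) on this reading. For compound 4 the estimated value is 1500 nM with an expected range from 250 nM to 15000 nM in this assay overall.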

Compound 4, half-maximal inhibitory concentration: 2240 nM
Estimate against measurement, compound 4: 1.5-fold (0.17 log units) below; the measured number falls inside the stated range.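

In this assay, piperidin-1-yl in place of methyl on the aromatic carbon gives an at least 22-fold lower number from compound 3 to compound 4 (1.34 log units; beyond the scatter), so a true number returns at this position with a group other than dimethylamino. The two nitrogen-linked groups do not read alike, though: piperidin-1-yl in place of dimethylamino gives a 4.9-fold higher number from compound 2 to compound 4 (0.69 log units; beyond the scatter), a modest move compared with the large one for methyl in place of dimethylamino, an at least 100-fold higher number from compound 2 to compound 3 (2.03 log units; beyond the scatter). Compound 3 reads > 50000 nM, which is a limit of the assay and not a number, and the step from it can only be counted from that limit: the limit of > 50000 nM in this assay, at which 2 of the 4 values shown sit.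

The compounds shown leave open whether morpholin-4-yl, diethylamino or a hydroxyl group at this position would read like compound 2 and compound 4 or like compound 3. Going by these compounds alone, they also leave open whether piperidin-1-yl would give a true number alongside the other aromatic group carried by compound 1, in place of the one shared by compound 2, compound 3 and compound 4.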